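Compound 4: a Sulfonamide Carrying an Ethyl Group

The source may hold more compounds than are shown below. What is called first, only, known or untested is meant among the compounds shown, and "the series" means these compounds.

Three compounds share one core and differ only in the group attached to a saturated chain carbon bound to an aromatic carbon. Compound 1 `CCCCNC(=O)NCc1ccc(CCCC)n(Cc2ccc(-c3ccccc3-c3nn[nH]n3)cc2)c1=O` gives 10 nM in a functional assay (aorta) for antagonist activity, with Oryctolagus cuniculus as the target; a lower number here means a stronger inhibitor, a higher number a weaker inhibitor. Compound 2 `CCCCc1ccc(CNC(=O)N(C)C)c(=O)n1Cc1ccc(-c2ccccc2-c2nn[nH]n2)cc1` gives 2 nM in this assay, and compound 3 `CCCCc1ccc(CNS(C)(=O)=O)c(=O)n1Cc1ccc(-c2ccccc2-c2nn[nH]n2)cc1` gives 2 nM. Compound 2 therefore stands level with compound 3, the two together at the lowest numbers of the three, while compound 1 sits at the highest: a 5.0-fold lower number from compound 1 to compound 2 (0.70 log units; beyond the scatter) and a 5.0-fold lower number from compound 1 to compound 3 (0.70 log units; beyond the scatter). Between compound 2 and compound 3 there is no change at the digits printed from compound 2 to compound 3 (within the scatter).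

Compound 4 `CCCCc1ccc(CN(CC)S(C)(=O)=O)c(=O)n1Cc1ccc(-c2ccccc2-c2nn[nH]n2)cc1` has not yet been measured. It differs from compound 2 in one place: ethyl(methylsulfonyl)amino in place of (dimethylcarbamoyl)amino on a saturated chain carbon bound to an aromatic carbon. For the measured compounds named here, the nearest measured step is the one from compound 2 to compound 3, where the same exchange of a carbonyl-based group for a methylsulfonyl group left the number unchanged. Going by the values given here, compound 4 goes one step further by also carrying an ethyl group on that nitrogen, and no measured pair shows that exchange, so the size of its effect is unknown. Compound 4 is therefore expected to stay close to compound 2 in this assay, with an estimated step of a 1.5-fold higher number from compound 2 to compound 4 (0.18 log units; within the scatter). The estimate for compound 4 is 3 nM, within a range from 1 nM to 12 nM.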

Compound 4, half-maximal inhibitory concentration: 2 nM
The estimate for compound 4 lay 1.5-fold (0.18 log units) above the measured number; measured number inside the range.
By their numbers in this assay, from the lowest: compounds 2, 3 and 4 (each within the scatter of the next); then compound 1.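

In this assay, putting an ethyl group on the sulfonamide nitrogen gives no change at the digits printed from compound 3 to compound 4 (within the scatter) and so, among these compounds, the hydrogen on that nitrogen is not needed to keep the number low. The full exchange gives no change at the digits printed from compound 2 to compound 4 (within the scatter) even though the group on the saturated chain carbon bound to an aromatic carbon goes from 1 hydrogen-bond donor in (dimethylcarbamoyl)amino to 0 in ethyl(methylsulfonyl)amino. Compound 4 also falls on the same side of the gap to the (butylcarbamoyl)amino group as compound 2 and compound 3 do, with a 5.0-fold lower number from compound 1 to compound 4 (0.70 log units; beyond the scatter) as its step, so the weaker number of compound 1 is not shared by a sulfonamide carrying a chain of this size on its nitrogen.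

How far this position stretches remains open, since a longer chain such as butyl or a benzyl group on the sulfonamide nitrogen, or a carboxylic acid or a basic amine at the end of that ethyl group, does not appear among these compounds. Nothing available here explains why the ethyl group leaves the number where it is.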